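Piperazine nitrogen substituent survey in an A2b binding series

A few compounds are considered here, and "the series" means these few. Any claim that something is new, unique, unknown or untested is made for them only; others in the source may bear on it.

Measured so far:
- compound 1, `CCCn1c(=O)[nH]c2nc(-c3ccc(S(=O)(=O)N4CCN(c5ccccc5C)CC4)cc3)[nH]c2c1=O`: 0.432 nM
- compound 2, `CCCn1c(=O)[nH]c2nc(-c3ccc(S(=O)(=O)N4CCN(Cc5ccc(Br)c(F)c5)CC4)cc3)[nH]c2c1=O`: 0.473 nM

Both compounds share the same core and differ only in the group on an amine nitrogen in a ring of the piperazine. In an assay on CHO cells for displacement of a labelled ligand from adenosine receptor A2b (Homo sapiens), read by scintillation counting, with a stated time of 75 min, in the presence of a further agent that is not named here (on this read-out lower numbers stand for stronger inhibition and higher numbers for weaker inhibition), compound 1 gives 0.432 nM, and compound 2 gives 0.473 nM. Going by the values given here, the single measured step, a 1.1-fold higher number from compound 1 to compound 2 (0.04 log units; within the scatter), so the two values cannot be ordered; compound 2 simply has the higher of the two numbers, with compound 1 close beside it.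

Compound 3 is `CCCn1c(=O)[nH]c2nc(-c3ccc(S(=O)(=O)N4CCN(C(C)c5ccccc5)CC4)cc3)[nH]c2c1=O`. Its change from compound 2 is 1-phenylethyl in place of 4-bromo-3-fluorobenzyl on an amine nitrogen in a ring. Among the compounds with values here, the only relevant precedent is the step from compound 1 to compound 2, in which exchanging an aryl substituent for a substituted benzyl on this nitrogen left the number within the scatter. Since moving from 2-methylphenyl to 4-bromo-3-fluorobenzyl changed nothing measurable, a further exchange to 1-phenylethyl is expected to stay within the scatter as well, so a 1.1-fold higher number from compound 2 to compound 3 (0.02 log units; within the scatter) is the estimate. Compound 3 is therefore expected to give about 0.5 nM in this assay, with a range of 0.2 nM to 1.3 nM.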

Compound 3, inhibition constant: 8.34 nM
Compound 3: the middle estimate sits 17-fold (1.22 log units) below what was measured, outside the stated range (above it).
By their numbers in this assay, from the lowest: compounds 1 and 2 (each within the scatter of the next); then compound 3.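

In this assay the group on this amine nitrogen in a ring cannot be exchanged freely: 1-phenylethyl brings an 18-fold higher number from compound 2 to compound 3 (1.25 log units; beyond the scatter) and also a 19-fold higher number from compound 1 to compound 3 (1.29 log units; beyond the scatter) while 2-methylphenyl and 4-bromo-3-fluorobenzyl, in compound 1 and compound 2, stay within the scatter of each other. The flat picture given by compound 1 and compound 2 therefore does not hold for every group carrying a six-membered aromatic ring at this position, and the position proves sensitive to a change that keeps that ring and alters the heavy-atom count only slightly. No supporting data bear on the reason for this large step.

The step to compound 3 changes two things at once, removing the bromine and fluorine and replacing the benzyl with 1-phenylethyl, so the compounds shown leave open which of the two goes with the higher number. A plain benzyl group on this nitrogen would separate these two changes, and 4-bromo-3-fluoro substitution on the ring of the 1-phenylethyl group would test the same question from the other side.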